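A nitrile in place of a methyl on the aryl ether

The compounds below may be only part of what the source reports. "The series", "measured", "known", "first", "only" and "open" are said of these compounds alone.

Of the compounds shown here, two sharing a core have been measured in an assay on microsomes from liver for inhibition of acyl-CoA desaturase 1 (Rattus norvegicus); a higher number here means a weaker inhibitor, a lower number a stronger inhibitor. Compound 1 `Cc1ccc(OC2CCN(c3ccc(-n4ccnc4)nn3)CC2)cc1` gives 527 nM in this assay. Compound 2 `CC(C)(C)c1nnc(-c2ccc(N3CCC(Oc4ccccc4C(F)(F)F)CC3)nn2)s1`, which carries a different group on the core and a trifluoromethyl on its phenyl ring, gives 710 nM in this assay. These two numbers lie within the usual scatter of each other, so nothing on these data sets compound 1 apart from compound 2; compound 1 simply holds one of two numbers of similar size.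

Compound 3 `N#Cc1ccccc1OC1CCN(c2ccc(-n3ccnc3)nn2)CC1` has not yet been measured. It differs from compound 1 in a single place: 2-cyanophenyl in place of 4-methylphenyl on an oxygen on a saturated carbon. Going by the values given here, no pair of measured compounds isolates this change, and compound 2 differs from compound 1 in more than one place, so its value shows only that a phenyl ether bearing a different substituent is compatible with inhibition in this assay. Among the compounds with values here, with no measured step to lean on, the author expects no step beyond the scatter in either direction, and estimates it as a 1.1-fold lower number from compound 1 to compound 3 (0.02 log units; within the scatter). Compound 3 is therefore estimated at 500 nM in this assay, with a range from 150 nM to 1600 nM.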

Compound 3, half-maximal inhibitory concentration: 236 nM
For compound 3 the middle estimate is 2.1-fold (0.33 log units) above the measured one, and the stated range covers the measured number.
By their numbers in this assay, from the lowest: compound 3; then compounds 1 and 2 (each within the scatter of the next).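

Putting 2-cyanophenyl in place of 4-methylphenyl on an oxygen on a saturated carbon, with the rest of compound 1 unchanged, gives a 2.2-fold lower number from compound 1 to compound 3 (0.35 log units; beyond the scatter) in this assay. Going by these compounds alone, this modest step is the first evidence that the group on this oxygen can alter the number beyond the scatter, whereas the earlier pair differed in more than one place and could not isolate this position; here, the entering group brings a nitrile and a hydrogen-bond acceptor that the leaving group does not have. No measurement shown here bears on why the number falls, so the step stands as an observation without an explanation.

Because the nitrile and the methyl also sit at differently numbered places on the phenyl ring, the compounds shown cannot separate the identity of the group from its place, which a phenyl carrying the nitrile where 4-methylphenyl carries its methyl would address. They also leave open how this position would respond to a primary amide, a carboxylic acid or an aminomethyl group on the phenyl ring.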